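Bromo for Methyl on a Rearranged Core

This account rests on a few compounds, and the source may have more. Where it says the series, first, only, none or still open, it means among the compounds named here.

Three compounds with a shared bicyclic core carrying an amino group and two substituted phenyl rings have been measured. Compound 1 `Nc1cc(-c2ccc(Br)cc2)nc2cc(-c3ccc(Cl)cc3)nn12` gives 76.2% in a functional assay on the whole organism (strain Wistar) for inhibition, with Rattus norvegicus as the target, read by paw edema, with stated times of 30 min and 4 h, at a dose of 50 mg/kg by the oral route; on this read-out lower numbers stand for less inhibition and higher numbers for more inhibition at the one dose given (going by the name of the read-out). Compound 2 `Cc1ccc(-c2cc(N)n3nc(-c4ccc(Cl)cc4)cc3n2)cc1` gives 81% in this assay. Compound 3 `Cc1ccc(-c2cc3nc(-c4ccc(Cl)cc4)cc(N)n3n2)cc1` has the same atoms as compound 2, joined differently; the difference between the two cores is not broken down here. In this assay compound 3 gives 67.9%, a number that stands within the scatter of the value of compound 1 and beyond the scatter below the value of compound 2.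

The change from compound 2 to compound 1 is bromo in place of methyl on an aromatic carbon, and its measured step is a number 4.8 percentage points lower from compound 2 to compound 1 (within the scatter). Compound 4 `Nc1cc(-c2ccc(Cl)cc2)nc2cc(-c3ccc(Br)cc3)nn12` arises from compound 3 by the same change, (bromo in place of methyl on an aromatic carbon), and the two place descriptions read the same word for word. Within the data shown here, because the one measured step of this kind, a number 4.8 percentage points lower from compound 2 to compound 1 (within the scatter), stays within the scatter, compound 4 is expected to sit close to compound 3, with an estimated step of a number 3.9 percentage points lower from compound 3 to compound 4 (within the scatter). The estimate for compound 4 in this assay is 64%, expected to fall between 52% and 76%.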

Compound 4, a percentage reported as inhibition, in the whole organism at one dose (the size of the read-out at that dose, not a potency): 65.5%
Compound 4: middle estimate off by 1.5 percentage points, on the low side; low and high end bracket the measured number.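

In this assay the exchange of 4-methylphenyl for 4-bromophenyl on the second core gives a measured step that reads a number 2.4 percentage points lower from compound 3 to compound 4 (within the scatter). Set beside the step for the same exchange on the other core, it does not differ: the same change on two cores in this assay, a number 4.8 percentage points lower (within the scatter) from compound 2 to compound 1 and a number 2.4 percentage points lower (within the scatter) from compound 3 to compound 4, 2.4 percentage points apart, within the scatter of two such steps. Among these compounds, in both pairs, then, bromo in place of methyl on an aromatic carbon, para to a large group, stays within the usual scatter, so the exchange carries from one core to the other as a step too small to tell from noise; this does not show that the two groups are interchangeable in general, since it rests on only two pairs, at one dose and on one read-out, and it says nothing of potency or of why the two groups read alike.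

The compounds shown leave open whether the same holds for other groups at this place on the ring, such as methoxy, a carboxylic acid or a longer chain such as propyl. They also leave open whether an exchange of the chloro on the other phenyl ring, or of the amino group on the shared core for an amide, would carry from one core to the other in the same way.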